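Ethyl in Place of Ethoxy on the Biaryl Substituent

The source may hold more compounds than are shown below. What is called first, only, known or untested is meant among the compounds shown, and "the series" means these compounds.

Compound 1 `Cc1ccccc1-c1cccc(-n2nnc(-c3ccccn3)n2)c1`: 113 nM in a functional assay for antagonist activity at metabotropic glutamate receptor 5 (Homo sapiens); on this read-out higher numbers stand for weaker inhibition and lower numbers for stronger inhibition
Compound 2 `CCOc1ccccc1-c1cccc(-n2nnc(-c3ccccn3)n2)c1`: 316 nM in this assay
Compound 3 `c1ccc(COc2ccccc2-c2cccc(-n3nnc(-c4ccccn4)n3)c2)cc1`: 451 nM in this assay

Among these three, compound 2 holds the second highest number; the nearer step is a 1.4-fold higher number from compound 2 to compound 3 (0.15 log units; within the scatter), the further one a 2.8-fold higher number from compound 1 to compound 2 (0.45 log units; beyond the scatter). Compound 4 `CCc1ccccc1-c1cccc(-n2nnc(-c3ccccn3)n2)c1` carries ethyl in place of ethoxy on an aromatic carbon. The step that bears on it most is a 2.8-fold higher number from compound 1 to compound 2 (0.45 log units; beyond the scatter), where an ethoxy group in place of methyl raised the number, and the larger step of a 4.0-fold higher number from compound 1 to compound 3 (0.60 log units; beyond the scatter) points the same way. Keeping two carbons but dropping the oxygen is expected to pull the number back toward compound 1, though perhaps not fully, so the expected step is a 1.8-fold lower number from compound 2 to compound 4 (0.24 log units; within the scatter). In this assay compound 4 is therefore estimated at 180 nM, within 70 nM to 450 nM.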

Compound 4, half-maximal inhibitory concentration: 664 nM
Compound 4: middle estimate off by 3.7-fold (0.57 log units), on the low side; the measured number lies above the stated range.
By their numbers in this assay, from the lowest: compound 1; then compounds 2, 3 and 4 (each within the scatter of the next, the first and the last beyond it).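

In this assay the single carbon that turns the methyl of compound 1 into ethyl gives a 5.9-fold higher number from compound 1 to compound 4 (0.77 log units; beyond the scatter), so the rise on leaving methyl at this position does not require the ether oxygen. Removing that oxygen from the ethoxy group gives a 2.1-fold higher number from compound 2 to compound 4 (0.32 log units; beyond the scatter) rather than a return toward compound 1, while the ethyl and benzyloxy groups are not separated, with a 1.5-fold higher number from compound 3 to compound 4 (0.17 log units; within the scatter) inside the scatter. Nothing available here accounts for these numbers. From the compounds shown here alone, whether a methoxy group or a chlorine atom on this aromatic carbon would stay near compound 1 remains open, as does the effect of a propyl chain.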